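From methoxy to methyl on compound 2

A few compounds are considered here, and "the series" means these few. Any claim that something is new, unique, unknown or untested is made for them only; others in the source may bear on it.

Compound 1 `O=C(Nc1ccc([N+](=O)[O-])cc1Cl)c1cc(F)ccc1O`: "not determined" (no result reported)
Compound 2 `COc1ccc(O)c(C(=O)Nc2ccc([N+](=O)[O-])cc2Cl)c1`: 67.1 10^-6 cm/s

In an ADME assay for permeability, using PAMPA (on this read-out higher numbers stand for higher permeability and lower numbers for lower permeability), compound 2 gives 67.1 10^-6 cm/s. Among the measured compounds shown here, this is the only number available so far, so compound 2 cannot yet be ranked against anything. No result was reported for compound 1.

Compound 3 `Cc1ccc(O)c(C(=O)Nc2ccc([N+](=O)[O-])cc2Cl)c1` has not yet been measured. It differs from compound 2 in one place, with methyl in place of methoxy on an aromatic carbon. For the measured compounds named here, no measured step shows what this swap does in this assay, so the data offer no direct guide. Going by the values given here, only one small group changes, so a step beyond the usual scatter of repeated measurements is not expected, and no clear direction can be expected either. The estimated change is a 1.0-fold higher number from compound 2 to compound 3 (0.02 log units; within the scatter). For compound 3 the estimated value is 70 10^-6 cm/s, with a likely range from 32 10^-6 cm/s to 140 10^-6 cm/s.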

Compound 3, apparent permeability: 134 10^-6 cm/s
The estimate for compound 3 lay 1.9-fold (0.28 log units) below the measured number, and the stated range covers the measured number.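

Within this assay the swap of methoxy for methyl on this aromatic carbon, para to a hydroxy group, gives a 2.0-fold higher number from compound 2 to compound 3 (0.30 log units; within the scatter) and this is the first step that can be read at this position. The methoxy brings one more heavy atom and a hydrogen-bond acceptor that the methyl lacks, yet on this pair of compounds that exchange stays within what repeated measurements of the same compound would show. Nothing available here bears on a cause for this step.

Two groups make a thin basis, so this pair does not show whether the position stays as undemanding for every substituent. An amine, a carboxylic acid or a longer chain such as ethoxy at the same carbon could give a step beyond the scatter or could not, and the compounds shown do not settle which.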